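This account rests on a few compounds, and the source may have more. Where it says the series, first, only, none or still open, it means among the compounds named here.

Compound 1, with the structure `O=C(/C=C/c1cccc(OCc2ccccc2)c1)c1ccc(Br)cc1`, is the weaker of the two measured compounds in a functional assay on MDA-MB-231 cells (Homo sapiens) for cytotoxicity, read by MTT assay, with a stated time of 68 h; a lower number here means a stronger inhibitor, a higher number a weaker inhibitor: compound 1 gives 6400 nM, the highest of the two numbers. Going by the values given here, its only measured neighbour is compound 2, `O=C(/C=C/c1cccc(OCc2ccccc2)c1)c1ccc(Cl)c(Cl)c1Cl`, which in this assay gives 2400 nM; the step of a 2.7-fold lower number from compound 1 to compound 2 (0.43 log units; beyond the scatter) is the single measured step here, and it changes the ring on the carbonyl carbon in a different way from what follows. Compound 3, `COc1ccc(C(=O)/C=C/c2cccc(OCc3ccccc3)c2)cc1`, has not yet been measured. It differs from compound 1 in one place: methoxy in place of bromo on an aromatic carbon. No measured step bears directly on exchanging bromo for methoxy, so the data give no reason to expect a change beyond the scatter. Compound 3 is therefore expected to give about 6000 nM, within a range from 2500 nM to 15000 nM. The expected step is a 1.1-fold lower number from compound 1 to compound 3 (0.03 log units; within the scatter).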

Compound 3, half-maximal inhibitory concentration: 12400 nM
Beside the measured number, compound 3's estimate is 2.1-fold (0.32 log units) below it; low and high end bracket the measured number.
By their numbers in this assay, from the lowest: compound 2; then compounds 1 and 3 (each within the scatter of the next).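

At the place para to a large group, exchanging bromo for methoxy in this assay gives a 1.9-fold higher number from compound 1 to compound 3 (0.29 log units; within the scatter), so this first change at that carbon, which brings in a hydrogen-bond acceptor, stays inside the usual scatter. The exchange of the whole ring on the carbonyl carbon, 4-methoxyphenyl in place of 2,3,4-trichlorophenyl, gives a 5.2-fold higher number from compound 2 to compound 3 (0.71 log units; beyond the scatter) and is a clearer difference, which sets compound 2 apart from both single-substituent compounds. Nothing available explains either result.

As far as these compounds go, whether any single group at this carbon can move the number beyond the scatter remains open, for example an amine, a carboxylic acid or a longer chain. Also open, from the compounds shown here alone, is which of the three chlorines in compound 2 matters, if any one does alone.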